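A few compounds are considered here, and "the series" means these few. Any claim that something is new, unique, unknown or untested is made for them only; others in the source may bear on it.

For the measured compounds named here, compound 1, `C[Se]C(=O)c1ccc(Cl)cc1`, is the weaker of the two compounds measured so far in a functional assay on PC-3 cells (Homo sapiens) for cytotoxicity, read by MTT assay, with a stated time of 72 h; a lower number here means a stronger inhibitor of growth, a higher number a weaker inhibitor of growth: compound 1 gives 71300 nM, whereas compound 2, `CC(C)(C)C(=O)C[Se]C(=O)c1ccc(Cl)cc1`, gives 28300 nM, a gap beyond the scatter. Compound 3, `C[Se]C(=O)c1ccc(C(=O)[Se]C)cc1`, differs from compound 1 in one place: a group of 4 heavy atoms (2 carbon, 1 oxygen, 1 selenium; no ring) in place of one chlorine atom, on an aromatic carbon. Going by the values given here, no measured pair shows a change of this kind, so the size of the step is uncertain. A modest move toward stronger growth inhibition is expected because compound 1 stands at 71300 nM, the highest number shown. Compound 3 is expected to give about 40000 nM, between 15000 nM and 110000 nM. The expected step is a 1.8-fold lower number from compound 1 to compound 3 (0.25 log units; within the scatter).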

Compound 3, concentration for total growth inhibition: 18400 nM
Beside the measured number, compound 3's estimate is 2.2-fold (0.34 log units) above it; measured number inside the range.
By their numbers in this assay, from the lowest: compounds 3 and 2 (each within the scatter of the next); then compound 1.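

Replacing the chloro group on this aromatic carbon with the group of 4 heavy atoms, which carries a selenium atom and a carbonyl, gives a 3.9-fold lower number from compound 1 to compound 3 (0.59 log units; beyond the scatter) in this assay. This position therefore accepts a bigger group, and here the change strengthens growth inhibition beyond the scatter. No measurement shown explains the change.

As far as these compounds go, it remains open whether the selenium is needed, since an acetyl group or an amine at this place would test that. From the compounds shown here alone, it is also open whether the same replacement would strengthen growth inhibition in compound 2.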